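The source may hold more compounds than are shown below. What is called first, only, known or untested is meant among the compounds shown, and "the series" means these compounds.

Compound 1 `O=C(CCCCC1CCSS1)Nc1ccccn1`: 39.3%
Compound 2 `O=C(CCCCC(S)CCS)Nc1ccccc1`: 25.4%

In a functional assay on NCI-H460 cells (Homo sapiens) for inhibition, read by MTT assay, with a stated time of 24 h, tested at 100 ug/mL (on this read-out higher numbers stand for more inhibition of growth at the one concentration tested and lower numbers for less inhibition of growth), compound 2 gives 25.4%. This is the lower of the two numbers, and its gap to compound 1 lies beyond the usual scatter.

Compound 3 `O=C(CCCCC(S)CCS)Nc1ccccn1` differs from compound 2 in one place: pyridin-2-yl in place of phenyl on an amide-type nitrogen. In words, pyridin-2-yl stands in place of phenyl on an amide-type nitrogen.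

Among the compounds with values here, no measured pair of compounds shows this change on its own, so its size cannot be read directly from the data. Within the data shown here, the only hint is compound 1, the one measured compound carrying pyridin-2-yl, at 39.3%. A small rise is therefore expected, probably not beyond the scatter. The expected step is a number 6.6 percentage points higher from compound 2 to compound 3 (within the scatter). Compound 3 is estimated at 32%, with an expected range of 19% to 45%.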

Compound 3, percent growth inhibition at one concentration: 11.7%
For compound 3 the middle estimate is 20.3 percentage points above the measured one; the measured number lies below the stated range.
By their numbers in this assay, from the lowest: compound 3; then compound 2; then compound 1.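

In this assay, within the data shown here, the swap on the amide-type nitrogen gives a number 13.7 percentage points lower from compound 2 to compound 3 (beyond the scatter) as the only change, so pyridin-2-yl in place of phenyl goes with less growth inhibition at this position. With pyridin-2-yl kept, replacing the five-membered non-aromatic ring with 2 hetero atoms by an open group of 5 heavy atoms gives a number 27.6 percentage points lower from compound 1 to compound 3 (beyond the scatter) in the same test, so the higher number of compound 1 is no guide to what pyridin-2-yl does in the open-chain compounds. Nothing measured here explains either step.

Whether the fall is particular to pyridin-2-yl stays open, as the compounds shown carry only these two groups on that nitrogen. A pyridin-3-yl or a benzyl group there could show whether the ring nitrogen's place matters.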